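The source may report more compounds than this note shows. Statements on the series, on what has been measured and on what is new or still open speak of the compounds shown alone.

Compound 1 `CCN(CC)C(=O)CN(c1cccc(N(C)C)c1C#N)S(=O)(=O)c1ccc(OC)c(OC)c1` is measured in a functional assay on CHO cells for inhibition of Orexin receptor type 2 (Homo sapiens), read by FLIPR and calcium flux (a higher number here means a weaker inhibitor, a lower number a stronger inhibitor), where compound 1 gives 110 nM. Of the three compounds measured this way, compound 1 has the second highest number: compound 2 `CCN(CC)C(=O)CN(c1cc(N(CC)CC)ccc1Cl)S(=O)(=O)c1ccc(OC)c(OC)c1` gives 2410 nM, a weaker result, while compound 3 `CCN(C(=O)CN(c1cc(N(C)C)ccc1Cl)S(=O)(=O)c1ccc(OC)c(OC)c1)c1cnc(C)cn1` gives 3 nM, a much stronger one, and both gaps lie beyond the usual scatter. Compound 4 `CCN(CC)C(=O)CN(c1cc(N(C)C)ccc1C#N)S(=O)(=O)c1ccc(OC)c(OC)c1` has not yet been measured. It differs from compound 1 in one place: 2-cyano-5-(dimethylamino)phenyl in place of 2-cyano-3-(dimethylamino)phenyl on a sulfonamide nitrogen. Going by the values given here, no measured pair isolates this rearrangement, so the direction of the step is uncertain, and the step from compound 1 to compound 4 is expected to be modest, a 2.8-fold lower number from compound 1 to compound 4 (0.44 log units; beyond the scatter). Compound 4 is therefore estimated to give 40 nM, with a likely range from 8 nM to 200 nM.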

Compound 4, half-maximal inhibitory concentration: 10 nM
Compound 4: the middle estimate sits 4.0-fold (0.60 log units) above what was measured; measured number inside the range.
By their numbers in this assay, from the lowest: compound 3; then compound 4; then compound 1; then compound 2.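

Replacing 2-cyano-3-(dimethylamino)phenyl with 2-cyano-5-(dimethylamino)phenyl on a sulfonamide nitrogen keeps the same atoms, yet this assay shows an 11-fold lower number from compound 1 to compound 4 (1.04 log units; beyond the scatter). This pair shows that, at this position, the arrangement of groups on the phenyl ring alone can produce a large step, not only the choice of groups. Nothing available here explains why this rearrangement has such an effect. From the compounds shown here alone, it remains open whether the lower number would hold with a methylamino group in place of dimethylamino, or with a fluorine in place of the nitrile.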